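The source may hold more compounds than are shown below. What is called first, only, known or untested is meant among the compounds shown, and "the series" means these compounds.

Measured compounds in the series:

compound 1, `COC(=O)C1=C(C)NC(=S)NC1c1ccoc1`, 48%
compound 2, `CCCOC(=O)C1=C(C)NC(=S)NC1c1ccoc1`, 45%
compound 3, `COC(=O)C1=C(C)NC(=S)NC1c1cccs1`, 10%

All three were read in an assay on membranes from HEK293 cells for displacement of a labelled ligand from adenosine receptor A2b (Homo sapiens), read by scintillation counting, with a stated time of 30 min, tested at 1 uM; on this read-out higher numbers stand for more inhibition at the one concentration tested (going by the name of the read-out) and lower numbers for less inhibition. Compound 1 gives 48% and compound 2 gives 45%. The change between them is ethyl in place of hydrogen on a saturated chain carbon bound to an oxygen next to a carbonyl group, and the step it made is a number 3 percentage points lower from compound 1 to compound 2 (within the scatter), so the two values are not separated by this assay.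

The core of compound 3 differs from that of compound 1 by thiophen-2-yl in place of furan-3-yl on a saturated ring carbon. This difference made the step of a number 38 percentage points lower from compound 1 to compound 3 (beyond the scatter), and compound 3, with 10%, stands lowest of the three numbers, separated from both compound 1 and compound 2.

Compound 4, `CCCOC(=O)C1=C(C)NC(=S)NC1c1cccs1`, has not been measured. It carries the core of compound 3 and differs from it by ethyl in place of hydrogen on a saturated chain carbon bound to an oxygen next to a carbonyl group, the same change that was made from compound 1 to compound 2, at the same place. Since that earlier change gave a number 3 percentage points lower from compound 1 to compound 2 (within the scatter), the expectation for compound 4 is a step of similar size, within the scatter of this assay, estimated as a number 2 percentage points lower from compound 3 to compound 4 (within the scatter). This expectation rests on a single earlier pair only, and the lower starting number of compound 3 gives little room downward. Compound 4 is therefore estimated at 8%, with a range from 0% to 20%.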

Compound 4, a percentage reported as inhibition, at one concentration (the size of the read-out at that concentration, not a potency): 3%
Compound 4: middle estimate off by 5 percentage points, on the high side; the range from low to high includes it.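

In this assay, ethyl in place of hydrogen on a saturated chain carbon bound to an oxygen next to a carbonyl group gave a number 7 percentage points lower from compound 3 to compound 4 (within the scatter), and this change carries from the core of compound 1 to the core of compound 3 with no difference that the assay can separate: the same change on two cores in this assay, a number 3 percentage points lower (within the scatter) from compound 1 to compound 2 and a number 7 percentage points lower (within the scatter) from compound 3 to compound 4, 4 percentage points apart, within the scatter of two such steps

Thiophen-2-yl in place of furan-3-yl on a saturated ring carbon, now read with propoxycarbonyl in place of methoxycarbonyl, gave a number 42 percentage points lower from compound 2 to compound 4 (beyond the scatter), so the large step also holds on both ester forms: the same change on two cores in this assay, a number 38 percentage points lower (beyond the scatter) from compound 1 to compound 3 and a number 42 percentage points lower (beyond the scatter) from compound 2 to compound 4, 4 percentage points apart, within the scatter of two such steps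

Among these compounds, this rests on only two pairs per change, at a single concentration, and the pairs ending at compound 3 and compound 4 lie at the low end of the read-out, so it shows neither potency nor that either change would transfer in the same way to other cores.

Open, on these data alone, is how the read-out responds to a longer chain such as butoxycarbonyl in place of propoxycarbonyl, or to a carboxylic acid in place of the ester. Also open, as far as these compounds go, is whether a phenyl group on the saturated ring carbon would read nearer to the furan-3-yl compounds or the thiophen-2-yl compounds.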